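The source may hold more compounds than are shown below. What is called first, only, known or untested is meant among the compounds shown, and "the series" means these compounds.

Measured compounds:
compound 1 `COc1ccc([C@@H]2CC(=O)c3c(O)cc(OCc4cn(C5CCCC5)nn4)cc3O2)cc1O` gives 10500 nM in a functional assay on RAW264.7 cells (Mus musculus) for inhibition, read by Griess assay, with stated times of 2 h and 24 h; a higher number here means a weaker inhibitor, a lower number a stronger inhibitor;
compound 2 `CCCn1cc(COc2cc(O)c3c(c2)O[C@H](c2ccc(OC)c(O)c2)CC3=O)nn1` gives 9670 nM in this assay;
compound 3 `CCCCn1cc(COc2cc(O)c3c(c2)O[C@H](c2ccc(OC)c(O)c2)C/C3=N\O)nn1` gives 8900 nM in this assay.

Compound 1 carries the highest of these three numbers, but the three lie close together. The shift a 1.1-fold lower number from compound 1 to compound 2 (0.04 log units; within the scatter) stays within the scatter of repeated measurements, and the numbers of compound 1 and compound 3, which differ at more than one place, are likewise too near one another to rank them.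

The step to the new compound 4 `COc1ccc([C@@H]2CC(=O)c3c(O)cc(OCc4cn(Cc5cccc(C)c5)nn4)cc3O2)cc1O` changes compound 1 at one place: 3-methylbenzyl in place of cyclopentyl on an aromatic nitrogen.

Among the measured compounds shown here, no measured pair shows this exact exchange. For the measured compounds named here, the only step that touches the same spot is the one in which the cyclopentyl gives way to propyl, a 1.1-fold lower number from compound 1 to compound 2 (0.04 log units; within the scatter), and that produced no shift beyond the scatter. On that single piece of evidence, replacing the cyclopentyl with a larger group at the same aromatic nitrogen is expected to leave the number of compound 4 near that of compound 1, with no direction favoured. The expected step is therefore a 1.1-fold lower number from compound 1 to compound 4 (0.04 log units; within the scatter), within the scatter. Compound 4 is estimated at 9500 nM, with a likely range from 4000 nM to 22000 nM.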

Compound 4, half-maximal inhibitory concentration: 17400 nM
Compound 4: the middle estimate sits 1.8-fold (0.26 log units) below what was measured; the range from low to high includes it.
By their numbers in this assay, from the lowest: compounds 3, 2, 1 and 4 (each within the scatter of the next).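

In this assay, an aromatic ring can be carried on this aromatic nitrogen without a shift that stands out from the scatter: the exchange of cyclopentyl for 3-methylbenzyl gives a 1.7-fold higher number from compound 1 to compound 4 (0.22 log units; within the scatter), and the exchange of ethyl for 3-methylphenyl on the saturated chain carbon gives a 1.8-fold higher number from compound 2 to compound 4 (0.26 log units; within the scatter). Together with the earlier step from cyclopentyl to propyl, this means that a chain, a five-membered non-aromatic ring of carbon and a group with a six-membered aromatic ring, which at 8 heavy atoms is larger than the 5 of cyclopentyl, cannot yet be told apart at this position. No measurement is available that bears on why these numbers stay so close.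

The compounds shown leave open whether a group of a different kind on this nitrogen, such as a chain ending in an amine or in a carboxylic acid, would move the number beyond the scatter. They also leave open whether plain benzyl, without the methyl, would give a number different from that of compound 4.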